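From methoxymethyl to ethyl: a question of clearance

The compounds below may be only part of what the source reports. "The series", "measured", "known", "first", "only" and "open" are said of these compounds alone.

Drug candidates are often judged by how quickly liver enzymes remove them. In an in vitro ADME assay on microsomes from liver (Homo sapiens) for metabolic stability (a lower number here means slower removal, a higher number faster removal of the compound), compound 1 `COCc1nc2nc(C)cc(Nc3ccc(C(F)(F)F)cc3)n2n1` gives 6.7 mL.min-1.g-1. Compound 3 `Cc1cc(Nc2ccc(Cl)cc2)n2nc(C(C)C)nc2n1` gives 14.1 mL.min-1.g-1, so compound 1 holds the lower of these two numbers, and the gap between them lies beyond the usual scatter. Compound 2 `Cc1cc(Nc2ccc(S(F)(F)(F)(F)F)cc2)n2nc(C3CC3)nc2n1` is reported at < 5 mL.min-1.g-1, which is a limit of the assay and not a number.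

Compound 4 `CCc1nc2nc(C)cc(Nc3ccc(C(F)(F)F)cc3)n2n1` keeps the core of compound 1 and differs in one place: methyl in place of methoxy on a saturated chain carbon bound to an aromatic carbon. This puts methyl in place of methoxy on a saturated chain carbon bound to an aromatic carbon, so methoxymethyl becomes ethyl. Among the measured compounds shown here, no measured pair here shows this change, so the expectation is cautious: no step beyond the scatter in this assay. The expected change, a 1.0-fold lower number from compound 1 to compound 4 (0.01 log units; within the scatter), is therefore small. For compound 4, the estimated clearance is 6.5 mL.min-1.g-1, with an expected range from 4 mL.min-1.g-1 to 12 mL.min-1.g-1.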

Compound 4, intrinsic clearance in microsomes: < 5 mL.min-1.g-1
Compound 4 gave a limit, no number (the forecaster's own chance of this, stated with the estimate: 30%); middle value at least 1.3-fold (0.11 log units) from the limit.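

Among the compounds shown here, putting methyl in place of methoxy on a saturated chain carbon bound to an aromatic carbon, so that methoxymethyl becomes ethyl, gives the first comparison at this position in which only one place differs, and in this assay it gives an at least 1.3-fold lower number from compound 1 to compound 4 (0.12 log units; that floor lies within the scatter). At this position, then, removing the methoxy group shows no sign of a higher number, although the printed floor of the step does not by itself set the two compounds apart. The true size of the step cannot be read, because compound 4 sits at a limit of the assay and not at a number: the limit of < 5 mL.min-1.g-1 in this assay, at which 2 of the 4 values shown sit.

As far as these compounds go, whether a longer chain such as propyl, or an amine, at this position would also keep the number this low remains open. How far the same change from methoxy to methyl carries over to other compounds on this core is open too.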